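The source may hold more compounds than are shown below. What is called first, only, known or untested is meant among the compounds shown, and "the series" means these compounds.

Compound 1 `COc1ncc(-c2ccc3c(c2)N(c2ccc(C)cc2)C(=O)CO3)cc1NS(=O)(=O)c1ccc(F)cc1`: 4650 nM
Compound 2 `COc1cccc(N2C(=O)COc3ccc(-c4cnc(Cl)c(NS(=O)(=O)c5ccc(F)cc5)c4)cc32)c1`: > 40000 nM

In a functional assay on HeLa cells (Homo sapiens) for antiproliferative activity, read by MTT assay, with a stated time of 72 h (on this read-out lower numbers stand for stronger inhibition and higher numbers for weaker inhibition), compound 1 gives a measured number, 4650 nM. Compound 2 gives only a limit, > 40000 nM. Compound 3 `O=C1COc2ccc(-c3cnc(Cl)c(NS(=O)(=O)c4ccc(F)cc4)c3)cc2N1C1CCCCC1` has cyclohexyl in place of 3-methoxyphenyl on an amide-type nitrogen in a ring. Within the data shown here, no measured step shows what this change does, so the expectation is uncertain, and compound 3 could also end up as a limit. A modest move towards stronger inhibition in this assay is expected, estimated as an at least 1.8-fold lower number from compound 2 to compound 3 (0.25 log units; that floor lies within the scatter). For compound 3 the expected value is 22000 nM, with an estimated range of 6000 nM to 40000 nM.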

Compound 3, half-maximal inhibitory concentration: 14300 nM
For compound 3 the middle estimate is 1.5-fold (0.19 log units) above the measured one, within the range that was stated.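

Putting cyclohexyl in place of 3-methoxyphenyl on the amide-type nitrogen in a ring gives an at least 2.7-fold lower number from compound 2 to compound 3 (0.44 log units; beyond the scatter) in this assay. Among these compounds, at this position, then, a non-aromatic ring of carbon still allows a measured number, which the earlier compounds did not show. Compound 2 carries a limit, so this step is only a floor and its full size stays unknown: the limit of > 40000 nM in this assay, at which 1 of the 3 values shown sits.

The compounds shown leave open what a methyl group or a longer chain would do on this nitrogen. They also leave open whether an amine on the cyclohexyl ring would change the number.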